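A Shorter Ester Chain on a Shared Core

A few compounds are considered here, and "the series" means these few. Any claim that something is new, unique, unknown or untested is made for them only; others in the source may bear on it.

Three compounds share a core carrying two isopropyl groups and a linker that holds both an amide and an ester. In an assay on microsomes from intestine for inhibition of acyl-CoA:cholesterol acyltransferase (Oryctolagus cuniculus) (on this read-out higher numbers stand for weaker inhibition and lower numbers for stronger inhibition), compound 1 `COc1cc(OC)c(NC(=O)CC(=O)Oc2c(C(C)C)cccc2C(C)C)c(OC)c1` gives 1000 nM. In this assay compound 2 `CCCCCCCCOC(=O)CC(=O)Nc1c(C(C)C)cccc1C(C)C` gives 260 nM, and compound 3 `COc1cc(OC)c(OC(=O)CC(=O)Nc2c(C(C)C)cccc2C(C)C)c(OC)c1` gives 320 nM. The number for compound 2 is the lowest of the three, yet its gap to compound 3 lies within the usual scatter, so these two cannot be told apart on this read-out; only its gap to compound 1 lies beyond the scatter.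

Compound 4 `CCCCCCOC(=O)CC(=O)Nc1c(C(C)C)cccc1C(C)C` has not yet been measured. It differs from compound 2 in one place: hydrogen in place of ethyl on a saturated chain carbon, six bonds along the chain from an oxygen next to a carbonyl group. For the measured compounds named here, no pair of measured compounds differs in a single place, so there is no measured step to lean on, and the three measured numbers give no direct guidance on chain length.

The expected step of a 1.5-fold higher number from compound 2 to compound 4 (0.19 log units; within the scatter) is small, toward a slightly higher number, and may well stay within the scatter. In this assay compound 4 is expected to give about 400 nM, with a plausible range from 150 nM to 1200 nM.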

Compound 4, half-maximal inhibitory concentration: 810 nM
Estimate against measurement, compound 4: 2.0-fold (0.31 log units) below, and the stated range covers the measured number.
By their numbers in this assay, from the lowest: compounds 2 and 3 (each within the scatter of the next); then compounds 4 and 1 (each within the scatter of the next).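

Here, for the first time, a single change can be read on its own in this assay: replacing ethyl with hydrogen on a saturated chain carbon, six bonds along the chain from an oxygen next to a carbonyl group, gives a 3.1-fold higher number from compound 2 to compound 4 (0.49 log units; beyond the scatter). The far end of the ester chain therefore counts on this read-out, since losing just these 2 carbon atoms weakens inhibition by a modest but readable step, even though the change removes no hydrogen-bond donor or acceptor and no charge. Nothing in the available data bears on why this step occurs.

Going by these compounds, a single step cannot show whether the trend continues along the chain, so it remains open how a shorter chain, such as butyl, or a longer one, such as decyl, would behave at this position. It is also unknown how the number would respond to an amine or a carboxylic acid at the chain end, or whether shortening the chain would have the same effect on the core of compound 1 or with the ring-bearing ester of compound 3.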